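The source may hold more compounds than are shown below. What is called first, only, known or untested is meant among the compounds shown, and "the series" means these compounds.

Working notes on the series in a toxicity assay on Huh-7 cells (Homo sapiens) for cytotoxicity, read by CCK-8 assay, with a stated time of 24 h; a lower number here means that less compound is tolerated, a higher number that more compound is tolerated. Compound 1 `O=c1cc(-c2ccccc2)oc2c(-c3ccccc3)c(O)c(O)c(O)c12` gives 86300 nM. Compound 2 `O=c1cc(-c2ccccc2)oc2c(-c3ccc(F)cc3)c(O)c(O)c(O)c12` reads > 100000 nM, which is a limit of the assay and not a number. Compound 3 `Cc1cccc(-c2c(O)c(O)c(O)c3c(=O)cc(-c4ccccc4)oc23)c1` reads > 100000 nM, which is also only a limit. Compound 3 therefore stands at the limit of > 100000 nM in this assay, at which 2 of the 3 values shown sit, and no exact value is available for it.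

Compound 4 `O=c1cc(-c2ccccc2)oc2c(-c3cc(F)cc(F)c3)c(O)c(O)c(O)c12` carries 3,5-difluorophenyl in place of 3-methylphenyl on an aromatic carbon.

Two measured changes on the same aryl group bear on this. Fluoro in place of hydrogen gives an at least 1.1-fold higher number from compound 1 to compound 2 (0.06 log units; that floor lies within the scatter), and methyl in place of hydrogen gives an at least 1.1-fold higher number from compound 1 to compound 3 (0.06 log units; that floor lies within the scatter). The direct comparison of the two substituted compounds gives a step that the two limits leave unreadable from compound 2 to compound 3.

With both readable steps no larger than floors within the scatter, no step beyond the scatter is expected in this assay, and the estimated change is a step that the limit leaves unreadable from compound 3 to compound 4. Compound 4 is expected at 110000 nM, with an estimated range of 70000 nM to 200000 nM, and a report as a limit only is quite likely.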

Compound 4, half-maximal cytotoxic concentration: > 100000 nM
Compound 4 gave a limit, no number; the forecaster's own chance of this, stated with the estimate: 70%; the middle value does not contradict the limit.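

In this assay, replacing phenyl with 3,5-difluorophenyl gives an at least 1.1-fold higher number from compound 1 to compound 4 (0.06 log units; that floor lies within the scatter), so this change shows no step beyond the scatter. The new information is that an aryl group carrying two fluorines, and not just one substituent, also gives only a limit at this position: the limit of > 100000 nM in this assay, at which 3 of the 4 values shown sit. As far as these compounds go, compounds 2, 3 and 4 all give limits, so the steps among them cannot be read, and their order stays unknown.

Compound 1 remains the only exact value, so the compounds shown do not establish whether any change on this aryl group can move the number clearly in either direction. Also open, from the compounds shown here alone, is how this assay responds to an amine, a carboxylic acid or a longer chain on this aryl group, or to replacing the aryl group with a chain.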